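The compounds below may be only part of what the source reports. "The series", "measured", "known", "first", "only" and "open" are said of these compounds alone.

Measured in an ADME assay on liver (Homo sapiens) for metabolic stability, read by LC-MS, using microsomes and NADPH; a higher number here means that more of the compound is left, a lower number that less of the compound is left:
- compound 1 `CCCN(Cc1ccc(OCCN2C(=O)CCC2=O)c(C)c1)[C@H](CC(=O)O)c1ccc(Cl)cc1`: 100%
- compound 2 `CCN(Cc1ccc(OCCN2C(=O)CCC2=O)c(C)c1)C(CC(=O)O)c1ccc(Cl)cc1`: 100%

Level with compound 1 within the scatter, compound 2 stands at 100%. Neither compound shows any loss in this assay, so the two values offer no contrast to learn from.

The next compound to be tested is compound 3 `Cc1cc(CN(CC2CCCCC2)C(CC(=O)O)c2ccc(Cl)cc2)ccc1OCCN1C(=O)CCC1=O`. It carries cyclohexyl in place of methyl on a saturated chain carbon bound to an amine nitrogen. Cut one bond further out, the same difference reads ethyl to cyclohexylmethyl, and the rest of the structure stays as it is in compound 2.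

For the measured compounds named here, no measured step covers a change of this kind, so the expectation is uncertain. Since compound 2 sits at 100%, there is no room for a rise, and any real movement can only be downward. A moderate fall somewhat beyond the scatter is expected, though no change at all remains possible. The expected step is a number 18 percentage points lower from compound 2 to compound 3 (beyond the scatter). For compound 3 the estimate is 82%, with an expected range from 55% to 100%.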

Compound 3, percent of the compound remaining: 47%
For compound 3 the middle estimate is 35 percentage points above the measured one, and the stated range ends above it.
By their numbers in this assay, from the lowest: compound 3; then compounds 1 and 2 (each within the scatter of the next).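

In this assay, cyclohexyl in place of methyl on a saturated chain carbon bound to an amine nitrogen comes with a number 53 percentage points lower from compound 2 to compound 3 (beyond the scatter) and brings the first loss of compound seen among those shown. The two earlier compounds both stood at the top of the read-out and could show only that nothing was lost, whereas compound 3 at 47% shows that this position is not indifferent to what it carries and that the assay can separate compounds here. Nothing at hand bears on why the number falls, and this single step gives no cause for it.

The compounds shown leave open whether the fall belongs to the ring of carbon itself or would also appear with an open chain, such as butyl or pentyl, at the same place, and whether a ring holding an ether oxygen, such as tetrahydropyranyl, would behave like cyclohexyl. They also leave open whether the same change would cost as much with an amide in place of the carboxylic acid.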